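Amide series: aryl swap from compound 3 to compound 4

The source may hold more compounds than are shown below. What is called first, only, known or untested is meant among the compounds shown, and "the series" means these compounds.

Three analogues with one shared amide core have been run in a functional assay on PC-3 cells (Homo sapiens) for cytotoxicity, read by MTT assay, with a stated time of 72 h; a lower number here means a stronger inhibitor, a higher number a weaker inhibitor. Compound 1 `Cc1cc(=O)n(-c2cccc(F)c2)nc1C(=O)Nc1ccc(Oc2ncnc3[nH]ccc23)c(F)c1` gives 6680 nM. Compound 2 `Cc1cc(=O)n(-c2cccc(F)c2)nc1C(=O)Nc1ccc(Oc2ncnc3c2ccn3C)cc1` reaches only the assay limit of > 60000 nM, so no number exists for it. Compound 3 `Cc1cc(=O)n(-c2ccc(Br)cc2F)nc1C(=O)Nc1ccc(Oc2ncnc3c2ccn3C)c(F)c1` gives 6670 nM, the lower of the two numbers, though its gap to compound 1 lies within the scatter. As far as these compounds go, compound 4 `Cc1cc(=O)n(-c2cccc(F)c2)nc1C(=O)Nc1ccc(Oc2ncnc3c2ccn3C)c(F)c1` is untested. It differs from compound 3 by 3-fluorophenyl in place of 4-bromo-2-fluorophenyl on an aromatic nitrogen, the 3-fluorophenyl in place of the 4-bromo-2-fluorophenyl on an aromatic nitrogen. Going by the values given here, no measured pair isolates this change; the 3-fluorophenyl is carried by compound 1 and compound 2, which differ from compound 4 elsewhere, so a small step is expected in this assay, if anything toward a weaker inhibitor. Compound 4 is estimated at 9000 nM, ranging from 3000 nM to 40000 nM. The expected step is a 1.3-fold higher number from compound 3 to compound 4 (0.13 log units; within the scatter).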

Compound 4, half-maximal inhibitory concentration: 8990 nM
The estimate for compound 4 lay 1.0-fold (0.00 log units) above the measured number, and the stated range covers the measured number.
By their numbers in this assay, from the lowest: compounds 3, 1 and 4 (each within the scatter of the next). At a limit, above all of these: compound 2.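

In this assay the aryl group on the aromatic nitrogen tolerates 3-fluorophenyl in place of 4-bromo-2-fluorophenyl, with a 1.3-fold higher number from compound 3 to compound 4 (0.13 log units; within the scatter) as the step. Methyl in place of hydrogen on an aromatic nitrogen also stays within the scatter, with a 1.3-fold higher number from compound 1 to compound 4 (0.13 log units; within the scatter) as its step. Fluoro in place of hydrogen on an aromatic carbon is the one step beyond the scatter, an at least 6.6-fold lower number from compound 2 to compound 4 (0.82 log units; beyond the scatter), and its size is only a bound, since compound 2 stands at a limit and not at a number: the limit of > 60000 nM in this assay, at which 1 of the 4 values shown sits.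

The compounds shown do not separate the bromine from the fluorine of the 4-bromo-2-fluorophenyl. As far as these compounds go, how an amine or a carboxylic acid on that aryl ring would read remains open.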